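Benzyl ester in place of the side-chain amide

The compounds below may be only part of what the source reports. "The series", "measured", "known", "first", "only" and "open" are said of these compounds alone.

Working notes on a short series of purine glycinamides built on a shared core. Compound 1 `C[C@@H](O)[C@H](NC(=O)CN(c1ncnc2c1ncn2C1CCCCO1)C1CC1)C(=O)OCc1ccccc1` carries a 1-hydroxyethyl group on the saturated chain carbon bound to an amide-type nitrogen and a carbonyl carbon; in a functional assay on the whole organism (Tail, strain ICR) with Mus musculus as the target, in the tail flick test, with a stated time of 150 min, at a dose of 25 umol/kg by the oral route (a higher number here means a stronger effect of the compound at the dose given, a lower number a weaker effect), compound 1 gives 6.53%. Among the measured compounds shown here, compound 2 `NC(=O)C[C@H](NC(=O)CN(c1ncnc2c1ncn2C1CCCCO1)C1CC1)C(=O)OCc1ccccc1` carries carbamoylmethyl at that position, and in this assay compound 2 gives 21.7%, the higher of the two numbers so far; the step of a number 15.2 percentage points higher from compound 1 to compound 2 (beyond the scatter) is the only measured step.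

Compound 3 `O=C(CN(c1ncnc2c1ncn2C1CCCCO1)C1CC1)N[C@@H](CC(=O)OCc1ccccc1)C(=O)OCc1ccccc1` is the next member, not yet measured. It differs from compound 2 by benzyloxy in place of amino on a carbonyl carbon, that is, carbamoyl becomes benzyloxycarbonyl. For the measured compounds named here, no measured step touches this kind of change: the one step on record, a number 15.2 percentage points higher from compound 1 to compound 2 (beyond the scatter), concerns a different exchange at a different place and gives no guide to direction here. The expectation is therefore a step of uncertain sign, most likely not beyond the scatter, expressed as a number 6.7 percentage points lower from compound 2 to compound 3 (within the scatter). For compound 3 the estimated result in this assay is 15%, expected to fall between 3% and 35%.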

Compound 3, a percentage reported as activity, at one dose (the size of the read-out at that dose, not a potency): 0.06%
Compound 3: the middle estimate sits 14.9 percentage points above what was measured; the measured number lies below the stated range.
By their numbers in this assay, from the lowest: compounds 3 and 1 (each within the scatter of the next); then compound 2.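

In this assay the exchange of amino for benzyloxy on the carbonyl carbon, carbamoyl to benzyloxycarbonyl, gives a number 21.6 percentage points lower from compound 2 to compound 3 (beyond the scatter) and so shows that the read-out responds to the end group on this carbonyl, and not only to the replacement of 1-hydroxyethyl seen earlier. The comparison with the first compound, a number 6.5 percentage points lower from compound 1 to compound 3 (within the scatter), leaves (benzyloxycarbonyl)methyl and 1-hydroxyethyl indistinguishable at this position, so among the three groups tested there only carbamoylmethyl, in compound 2, stands beyond the scatter from both others. Nothing available here explains why the carbamoylmethyl compound stands apart.

Open, on these data alone, is whether the gain depends on the intact carbamoyl or would also appear with a free carboxylic acid, a methyl ester or a methylamide at the same carbonyl carbon, and whether a longer chain such as carbamoylethyl would keep it. Also open, as far as these compounds go, is whether the stronger effect seen with compound 2 would hold at other doses and times, since the read-out reports the size of the effect at a single dose and a single time.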